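The compounds below may be only part of what the source reports. "The series", "measured", "known", "first", "only" and "open" are said of these compounds alone.

Values in a functional assay on HeLa cells (Homo sapiens) for antiproliferative activity, read by cell counting, with a stated time of 2 days; on this read-out lower numbers stand for stronger inhibition and higher numbers for weaker inhibition:
- Compound 1 `COc1cc(C(=O)c2sc(N(C)Cc3ccccc3)nc2N)cc(OC)c1OC`: > 200000 nM, a limit.
- Compound 2 `COc1ccc(C(=O)c2sc(N3CCCC3)nc2N)cc1OC`: 36000 nM.
- Compound 3 `COc1ccc(C(=O)c2sc(N3CCCC3)nc2N)cc1`: > 200000 nM, a limit.

Compound 3 has no numerical value, only the limit > 200000 nM. Compound 1 also reads as a limit, so the series stands at the limit of > 200000 nM in this assay, at which 2 of the 3 values shown sit, and compound 2 alone has a number.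

The next analogue is compound 4 `Nc1nc(N2CCCC2)sc1C(=O)c1ccc(Cl)cc1`. The change is chloro in place of methoxy on an aromatic carbon, para to a large group.

For the measured compounds named here, the one measured step bearing on this is an at least 5.5-fold higher number from compound 2 to compound 3 (0.74 log units; beyond the scatter), where hydrogen takes the place of methoxy on an aromatic carbon. It concerns another methoxy, but it shows activity in this assay falling as methoxy is lost from that ring. Compound 4 carries no methoxy there, so no recovery is expected, and no step beyond the scatter is expected either. The expected result is a number no higher from compound 3 to compound 4 (the limit leaves the size open), with the reading likely to remain at the limit. For compound 4 the estimated value is 200000 nM, with an expected range of 60000 nM to 400000 nM.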

Compound 4, half-maximal inhibitory concentration: > 200000 nM
Compound 4: a limit, no number (the forecaster's own chance of this, stated with the estimate: 75%); the middle value lies on the limit itself.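

In this assay, for the compounds shown here, compound 3 and compound 4 both read as limits, so no step between them can be read: the limit of > 200000 nM in this assay, at which 3 of the 4 values shown sit. Whether chloro or methoxy gives the lower number on that ring stays open, and compound 2 remains the only compound shown with a number.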